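Swapping a Pyridine for a Furan on a Shared Core

The source may report more compounds than this note shows. Statements on the series, on what has been measured and on what is new or still open speak of the compounds shown alone.

Among the compounds with values here, compound 1 `Oc1ccc(-c2cc(-c3ccc(Cl)cc3)nc(-c3cccnc3)c2)cc1` is the only member of this set with a number: in a functional assay on HCT-15 cells (Homo sapiens) for cytotoxicity, read by CCK-8 assay and cell counting, with a stated time of 2 days (on this read-out lower numbers stand for stronger inhibition and higher numbers for weaker inhibition), compound 1 gives 20700 nM, which is the sole value shown. Compound 2 `Oc1ccc(-c2cc(-c3cccnc3)nc(-c3ccccc3Cl)c2)cc1` was also prepared, yet in this assay compound 2 gives "not determined" (no result reported), so no comparison with it is possible. Compound 3 `Oc1ccc(-c2cc(-c3ccc(Cl)cc3)nc(-c3ccco3)c2)cc1` differs from compound 1 by one change: furan-2-yl in place of pyridin-3-yl on an aromatic carbon. Within the data shown here, with no step between measured compounds to guide this, the step of a 1.3-fold lower number from compound 1 to compound 3 (0.11 log units; within the scatter) is expected to be small, within the usual scatter. Compound 3 is therefore estimated at 16000 nM, with a range from 5000 nM to 50000 nM.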

Compound 3, half-maximal inhibitory concentration: 7020 nM
Beside the measured number, compound 3's estimate is 2.3-fold (0.36 log units) above it; low and high end bracket the measured number.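

Putting furan-2-yl in place of pyridin-3-yl next to the ring nitrogen gives a 2.9-fold lower number from compound 1 to compound 3 (0.47 log units; beyond the scatter) in this assay. This position is therefore sensitive to which aromatic ring it carries, and a five-membered aromatic ring with oxygen is accepted here with a modest gain. Nothing measured here explains the shift.

The compounds shown leave open how this position would respond to a thiophene ring, a plain phenyl ring or an amine. They also leave open whether the ring's size or its hetero atom drives the step.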